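Ethoxy in Place of Fluoro: an Expected Antiproliferative Read-out

The source may hold more compounds than are shown below. What is called first, only, known or untested is meant among the compounds shown, and "the series" means these compounds.

Three compounds built on one shared core have been examined in a functional assay on A-375 cells (Homo sapiens) for antiproliferative activity, read by MTT assay, with a stated time of 24 h, tested at 0.02 ug/mL; on this read-out lower numbers stand for a weaker effect and higher numbers for a stronger effect at the one concentration tested. Compound 1 `Cc1ccc2nc(C(=O)Nc3c(F)cc(-c4cccc(F)c4)cc3F)c(C)c(O)c2c1` gives 0.38%. Compound 2 `CCc1ccc2nc(C(=O)Nc3c(F)cc(-c4cccc(F)c4)cc3F)c(C)c(O)c2c1` gives -0.12% in this assay, and compound 3 `Cc1c(C(=O)Nc2c(F)cc(-c3cccc(F)c3)cc2F)nc2ccc(F)cc2c1O` gives -0.13%. The three numbers sit within the scatter of one another: a number 0.5 percentage points lower from compound 1 to compound 2 (within the scatter), a number 0.5 percentage points lower from compound 1 to compound 3 (within the scatter) and a number 0 percentage points lower from compound 2 to compound 3 (within the scatter). Compound 3 thus stands at a value that cannot be told apart from those of compound 1 and compound 2.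

Compound 4 `CCOc1ccc2nc(C(=O)Nc3c(F)cc(-c4cccc(F)c4)cc3F)c(C)c(O)c2c1` has not yet been measured in this assay. It differs from compound 3 by ethoxy in place of fluoro on an aromatic carbon. The measured steps that bear on this change are those in which the fluoro of compound 3 replaces an alkyl group, a number 0.5 percentage points lower from compound 1 to compound 3 (within the scatter) and a number 0 percentage points lower from compound 2 to compound 3 (within the scatter); both lie within the scatter. Among the compounds with values here, no measured step introduces an ethoxy, so the expectation rests only on the flatness of the series. Compound 4 is therefore expected to give 0.2% in this assay, between -5% and 6%. The step this estimate means, a number 0.3 percentage points higher from compound 3 to compound 4 (within the scatter), is expected to stay within the scatter.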

Compound 4, a percentage reported as inhibition, at one concentration (the size of the read-out at that concentration, not a potency): 0.68%
Beside the measured number, compound 4's estimate is 0.5 percentage points below it; the range from low to high includes it.
By their numbers in this assay, from the lowest: compounds 3, 2, 1 and 4 (each within the scatter of the next).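

Ethoxy is the only group shown at this aromatic carbon that brings a hydrogen-bond acceptor, and in this assay its exchange for fluoro gives a number 0.8 percentage points higher from compound 3 to compound 4 (within the scatter) as the step. The exchange for ethyl gives a number 0.8 percentage points higher from compound 2 to compound 4 (within the scatter) and the exchange for methyl gives a number 0.3 percentage points higher from compound 1 to compound 4 (within the scatter) so the flat read-out now extends across all four groups at this position, including one that places an oxygen on the aromatic carbon. Nothing measured here explains why these groups cannot be told apart.

Going by these compounds, whether a very different group at this position, such as an amine, a carboxylic acid or a longer alkoxy chain, would separate from these four remains open. Also open, on these data alone, is whether the four would still be indistinguishable at a higher concentration or after a longer exposure.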